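This account rests on a few compounds, and the source may have more. Where it says the series, first, only, none or still open, it means among the compounds named here.

Measured so far in an assay on HeLa cells for inhibition of sphingosine-1-phosphate transporter SPNS2 (Mus musculus), read by LC-MS, tested at 2 uM; a higher number here means more inhibition at the concentration tested (going by the name of the read-out), a lower number less inhibition:
- compound 1 `CCCCCCCCCCc1ccc(-c2noc(CN)n2)cc1`: 62%
- compound 2 `CCCCCCCCCCc1ccc(-c2noc([C@H]3CCCN3)n2)cc1`: 12%

Compound 2 stands lowest of the two numbers. Within the data shown here, the single measured step, a number 50 percentage points lower from compound 1 to compound 2 (beyond the scatter), came with pyrrolidin-2-yl in place of aminomethyl on an aromatic carbon.

Compound 3 `CCCCCCCCCCc1ccc(-c2noc(-c3cccc(CN)c3)n2)cc1` is not yet measured. The change is 3-(aminomethyl)phenyl in place of pyrrolidin-2-yl on an aromatic carbon. The aminomethyl of compound 1 thus returns, now carried on a phenyl. Among the measured compounds shown here, the only step that bears on this is a number 50 percentage points lower from compound 1 to compound 2 (beyond the scatter), a large loss on removing aminomethyl; its partial reversal is expected to give a number 33 percentage points higher from compound 2 to compound 3 (beyond the scatter). For the measured compounds named here, the phenyl has no measured counterpart, so the range is wide. Compound 3 is expected at 45%, between 15% and 75%.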

Compound 3, a percentage reported as inhibition, at one concentration (the size of the read-out at that concentration, not a potency): 2%
The estimate for compound 3 lay 43 percentage points above the measured number; measured number below the stated range.
By their numbers in this assay, from the lowest: compounds 3 and 2 (each within the scatter of the next); then compound 1.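

In this assay, aminomethyl carried on a phenyl does not keep what aminomethyl gives directly on the aromatic carbon, with 3-(aminomethyl)phenyl in its place giving a number 60 percentage points lower from compound 1 to compound 3 (beyond the scatter). Exchanging pyrrolidin-2-yl for 3-(aminomethyl)phenyl gives a number 10 percentage points lower from compound 2 to compound 3 (within the scatter), so these two groups cannot be told apart here. No measurement on hand explains either step.

Going by these compounds, what stays open is whether the amine alone accounts for the number of compound 1. An aminoethyl chain or a carboxylic acid at this position would bear on that question.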